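Compound 2 gains an acetyl group

A few compounds are considered here, and "the series" means these few. Any claim that something is new, unique, unknown or untested is made for them only; others in the source may bear on it.

In a physicochemical assay for lipophilicity, read by HPLC (a lower number here means a more polar compound, a higher number a more lipophilic compound), compound 2 `Cc1ccsc1C(=CCCN(C)C(CCN)C(=O)NCc1ccccc1Cl)c1sccc1C` reads 6.11. Compound 1 `Cc1ccsc1C(=CCCN(C)C(CCN)C(=O)NCc1ccc(Cl)cc1)c1sccc1C` reads 5.85, and these two values lie within the scatter of each other, while compound 3 `Cc1ccsc1C(=CCCN(C)C(CCN)C(=O)NCc1ccccc1)c1sccc1C` sits clearly lower at 5.5. Compound 4 `CC(=O)NCCC(C(=O)NCc1ccccc1Cl)N(C)CCC=C(c1sccc1C)c1sccc1C` differs from compound 2 by acetyl in place of hydrogen on an amine nitrogen, in short acetyl in place of hydrogen on an amine nitrogen. The measured steps concern only chloro: one is a number 0.26 log units higher from compound 1 to compound 2 (within the scatter), and the two with hydrogen in place of chloro on an aromatic carbon are a number 0.35 log units lower from compound 1 to compound 3 (beyond the scatter) and a number 0.61 log units lower from compound 2 to compound 3 (beyond the scatter). None touches that nitrogen, so they offer only a sense of scale. The expected change is a number 0.09 log units higher from compound 2 to compound 4 (within the scatter), so no step beyond the scatter is expected. The estimate for compound 4 is 6.2, with an expected range of 5.6 to 6.8.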

Compound 4, partition coefficient: 6.46
Compound 4: the middle estimate sits 0.26 log units below what was measured; measured number inside the range.
By their numbers in this assay, from the lowest: compound 3; then compounds 1 and 2 (each within the scatter of the next); then compound 4.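

In this assay, acetyl in place of hydrogen on this amine nitrogen gives a number 0.35 log units higher from compound 2 to compound 4 (beyond the scatter). This is the first step shown at this position, as the earlier steps concerned only chloro. It shows that a change at this nitrogen can move the number beyond the scatter, at least in a compound carrying the 2-chlorophenyl group, but nothing available explains the step.

From the compounds shown here alone, whether acetyl shifts the number similarly in compound 1 or compound 3 remains open. So does how a propanoyl or methanesulfonyl group on the same nitrogen would read.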